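A few compounds are considered here, and "the series" means these few. Any claim that something is new, unique, unknown or untested is made for them only; others in the source may bear on it.

Measured compounds: compound 1 `CCCCCCNc1nc(SCc2ccc(C(F)(F)F)cc2)nc2ccccc12` with 23900 nM in a functional assay on HGC-27 cells (Homo sapiens) for cytotoxicity, read by MTT assay, with a stated time of 72 h (on this read-out higher numbers stand for weaker inhibition and lower numbers for stronger inhibition), and compound 2 `CCCCCCCCNc1nc(SCc2ccc(C(F)(F)F)cc2)nc2ccccc12` with 13400 nM.

Compound 2 gives the lowest of the two numbers in this assay; its nearest neighbour is compound 1, and the step of a 1.8-fold lower number from compound 1 to compound 2 (0.25 log units; within the scatter) stays within the scatter. Compound 3 `CCCCCCCCCCCCNc1nc(SCc2ccc(C(F)(F)F)cc2)nc2ccccc12` carries butyl in place of hydrogen on a saturated chain carbon, eight bonds along the chain from a nitrogen on an aromatic ring. Among the measured compounds shown here, the only step that bears on this change is the one from compound 1 to compound 2, a lengthening of the same chain, and it was small. The change to compound 3 extends the chain further, so a modest shift toward a lower number is expected in this assay, a 1.5-fold lower number from compound 2 to compound 3 (0.17 log units; within the scatter), though it may not exceed the scatter. Compound 3 is therefore expected to give about 9000 nM, with a range from 3000 nM to 30000 nM.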

Compound 3, half-maximal inhibitory concentration: 38700 nM
The estimate for compound 3 lay 4.3-fold (0.63 log units) below the measured number, and the stated range ends below it.
By their numbers in this assay, from the lowest: compounds 2, 1 and 3 (each within the scatter of the next, the first and the last beyond it).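

In this assay, this position does not tolerate every chain length equally: butyl in place of hydrogen on the saturated chain carbon gives a 2.9-fold higher number from compound 2 to compound 3 (0.46 log units; beyond the scatter), the first step along this chain to exceed the scatter. The dodecyl chain of compound 3 still does not separate from the hexyl chain, since a 1.6-fold higher number from compound 1 to compound 3 (0.21 log units; within the scatter) stays within the scatter. Nothing available explains this result. Open, on these data alone, is where a decyl chain would fall relative to compound 2 and compound 3, and whether an amine at the chain end would shift the number.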